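A Methoxy Removed Twice on Two Related Cores

The compounds below may be only part of what the source reports. "The series", "measured", "known", "first", "only" and "open" are said of these compounds alone.

In a functional assay on SK-MEL-2 cells (Homo sapiens) for cytotoxicity, read by sulforhodamine B assay, with a stated time of 48 h, tested at 0.01 uM (a higher number here means a weaker effect of the compound at the concentration tested, a lower number a stronger effect), compound 1 `COc1cc(-c2cc(/C=C/C(=O)c3ccc(N)cc3)[nH]n2)cc(OC)c1OC` gives 106%. Compound 2 `COc1ccc(-c2cc(/C=C/C(=O)c3ccc(N)cc3)[nH]n2)cc1OC` differs from it by hydrogen in place of methoxy on an aromatic carbon and gives 103%, a step of a number 3 percentage points lower from compound 1 to compound 2 (within the scatter). Compound 3 `COc1cc(C(=O)/C=C/c2cc(-c3cc(OC)c(OC)c(OC)c3)n[nH]2)cc(OC)c1OC` gives 104%; its value and those of compound 1 and compound 2 all lie within the scatter of one another. How the core of compound 3 differs from the core of compound 1 is not broken down here. Compound 4 `COc1ccc(-c2cc(/C=C/C(=O)c3cc(OC)c(OC)c(OC)c3)[nH]n2)cc1OC` is compound 3 with hydrogen in place of methoxy on an aromatic carbon, the same change that leads from compound 1 to compound 2. Because a number 3 percentage points lower from compound 1 to compound 2 (within the scatter) stayed within the scatter, a step of like size is expected for compound 4 a number 3 percentage points lower from compound 3 to compound 4 (within the scatter). Compound 4 is therefore estimated at 101%, between 92% and 111%.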

Compound 4, a percentage reported as activity, at one concentration (the size of the read-out at that concentration, not a potency): 100%
Beside the measured number, compound 4's estimate is 1 percentage points above it; the measured number falls inside the stated range.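

In this assay, hydrogen in place of methoxy on an aromatic carbon gives a number 4 percentage points lower from compound 3 to compound 4 (within the scatter), and this step sits beside the earlier one on the core of compound 1: the same change on two cores in this assay, a number 3 percentage points lower (within the scatter) from compound 1 to compound 2 and a number 4 percentage points lower (within the scatter) from compound 3 to compound 4, 1 percentage points apart, within the scatter of two such steps. On these two cores, then, the change carries over as a step that stays within the scatter each time. This does not show that the change has any real effect on either core, and two cores make no rule for the series, while a read-out at a single concentration says nothing about potency.

The compounds shown leave open what a hydroxyl, an ethoxy group or a fluorine would do in place of that methoxy on either core.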